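Aryl exchange on the ring nitrogen: compound 2 to compound 3

The compounds below may be only part of what the source reports. "The series", "measured", "known", "first", "only" and "open" are said of these compounds alone.

Measured so far:
compound 1, `N#CC1=C(N)Oc2c(c3nc4ccccc4nc3c3ccccc23)C12C(=O)N(Cc1cnnn1-c1ccccc1Cl)c1ccccc12`: > 50000 nM
compound 2, `N#CC1=C(N)Oc2c(N)cc3nc4ccccc4nc3c2C12C(=O)N(Cc1cnnn1-c1ccc([N+](=O)[O-])cc1)c1ccccc12`: > 50000 nM

In an ADME assay on HUVEC cells (Homo sapiens) for antiproliferative activity, read by MTT assay, with a stated time of 48 h (on this read-out higher numbers stand for weaker inhibition and lower numbers for stronger inhibition), compound 1 gives only the limit > 50000 nM. Compound 2 likewise gives only the limit > 50000 nM in this assay. Both values sit at the limit of > 50000 nM in this assay, at which 2 of the 2 values shown sit, so compound 2 stands at the limit and no order between the two can be read. Compound 3, `Cc1cc(C)c(-n2nncc2CN2C(=O)C3(C(C#N)=C(N)Oc4c(N)cc5nc6ccccc6nc5c43)c3ccccc32)c(C)c1`, differs from compound 2 by 2,4,6-trimethylphenyl in place of 4-nitrophenyl on an aromatic nitrogen. Among the measured compounds shown here, no step between measured compounds is available, so the step in this assay cannot be calibrated from the series. Compound 3 is expected to stay at the limit, the step that the limit leaves unreadable from compound 2 to compound 3 being estimated as none beyond the scatter. The estimate for compound 3 in this assay is 60000 nM, range 20000 nM to 200000 nM.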

Compound 3, half-maximal inhibitory concentration: > 50000 nM
Compound 3: a limit, no number (the forecaster's own chance of this, stated with the estimate: 75%); the middle value does not contradict the limit.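

In this assay compound 2 and compound 3 both stand only as limits, and no step can be read between them. The compounds shown leave open whether 2,4,6-trimethylphenyl and 4-nitrophenyl on the aromatic nitrogen differ in antiproliferative activity at all.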